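This account rests on a few compounds, and the source may have more. Where it says the series, first, only, none or still open, it means among the compounds named here.

In a functional assay on CHO cells for antagonist activity at transient receptor potential cation channel subfamily V member 1 (Rattus norvegicus) (on this read-out lower numbers stand for stronger inhibition and higher numbers for weaker inhibition), compound 2 `COc1cc(C(C)(C)C(=O)NCC(COC(=O)C(C)(C)C)Cc2ccc(C)c(C)c2)ccc1NS(C)(=O)=O` gives 133 nM. Compound 1 `Cc1ccc(CC(CNC(=O)C(C)(C)c2ccc(NS(C)(=O)=O)cc2)COC(=O)C(C)(C)C)cc1C` gives 104 nM, and compound 3 `COc1cc(C2(C(=O)NCC(COC(=O)C(C)(C)C)Cc3ccc(C)c(C)c3)CC2)ccc1NS(C)(=O)=O` gives 118 nM; the three numbers lie within the usual scatter of one another, so none of them can be told apart from the others on these data. Compound 4 `Cc1ccc(CC(CNC(=O)C(C)(C)c2ccc(NS(C)(=O)=O)c(F)c2)COC(=O)C(C)(C)C)cc1C` has not yet been measured. It differs from compound 2 in one place: fluoro in place of methoxy on an aromatic carbon. Among the compounds with values here, one measured step bears on this carbon. There a methoxy group took the place of hydrogen, and the read-out moved by a 1.3-fold higher number from compound 1 to compound 2 (0.11 log units; within the scatter), a change too small to count. Within the data shown here, no measured pair shows fluoro at this carbon, so how fluoro compares with methoxy there is not known from these compounds. Among the measured compounds shown here, because a 1.3-fold higher number from compound 1 to compound 2 (0.11 log units; within the scatter) is the only change seen at this carbon and it left the read-out essentially unchanged, the step to compound 4 in this assay is expected to stay within the scatter, a 1.2-fold lower number from compound 2 to compound 4 (0.06 log units; within the scatter), with no direction favoured. Compound 4 is therefore estimated at 115 nM in this assay, within a range from 50 nM to 260 nM.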

Compound 4, inhibition constant: 65 nM
The estimate for compound 4 lay 1.8-fold (0.25 log units) above the measured number; the measured number falls inside the stated range.
By their numbers in this assay, from the lowest: compounds 4, 1, 3 and 2 (each within the scatter of the next, the first and the last beyond it).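

In this assay, the carbon ortho to a methanesulfonamido group now shows its first change beyond the scatter: fluoro in place of methoxy gives a 2.0-fold lower number from compound 2 to compound 4 (0.31 log units; beyond the scatter), a modest step at the very edge of what can be told apart. The earlier compounds shown here compared only hydrogen with methoxy, which could not be separated, whereas fluoro in place of hydrogen gives a 1.6-fold lower number from compound 1 to compound 4 (0.20 log units; within the scatter), also within the scatter, so hydrogen cannot be separated from either group and only fluoro and methoxy differ from each other. Nothing measured here accounts for that difference between fluoro and methoxy.

The compounds shown leave open how other groups on this carbon, such as chloro, hydroxyl or an amine, would compare with fluoro and methoxy in this assay. They also leave open whether the same exchange of methoxy for fluoro would give a similar step on the core of compound 3, which carries the methoxy group but has no fluoro partner here.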